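Replacing methoxy with chloro in compound 2

The source may hold more compounds than are shown below. What is called first, only, known or untested is meant among the compounds shown, and "the series" means these compounds.

In a functional assay on the whole organism with Mus musculus as the target, with a stated time of 30 min (on this read-out higher numbers stand for an effect only at larger amounts of compound and lower numbers for an effect already at smaller amounts), compound 1 `Nc1nnc(-c2ccccc2OCc2ccccc2F)o1` gives 9 mg/kg. Compound 2 `COc1ccc(N2C(=S)N=C(c3ccccc3)CC2c2ccccc2)cc1` gives 378 mg/kg, the higher of the two numbers and beyond the scatter from compound 1. Compound 3 `S=C1N=C(c2ccccc2)CC(c2ccccc2)N1c1ccc(Cl)cc1` keeps the core of compound 2 but has chloro in place of methoxy on an aromatic carbon, para to a large group (chloro in place of methoxy on an aromatic carbon). Going by the values given here, no measured pair shows the effect of such a change, so no step beyond the scatter is expected, with a slight lean towards a lower number. The estimated step runs a 1.5-fold lower number from compound 2 to compound 3 (0.18 log units; within the scatter). For compound 3 the expected value is 250 mg/kg, with an estimated range from 80 mg/kg to 600 mg/kg.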

Compound 3, dose for half-maximal effect: 312 mg/kg
Estimate against measurement, compound 3: 1.2-fold (0.10 log units) below, and the stated range covers the measured number.
By their numbers in this assay, from the lowest: compound 1; then compounds 3 and 2 (each within the scatter of the next).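

Going by these compounds alone, the first measured pair at this position, 4-methoxyphenyl to 4-chlorophenyl in this assay, gives a 1.2-fold lower number from compound 2 to compound 3 (0.08 log units; within the scatter), so this read-out does not separate the two groups here. This holds for this one pair on the shared core only. No measurement shown bears on the reason for this result.

As far as these compounds go, it remains open whether an amine, a carboxylic acid or a longer chain such as butoxy at this place would move the number beyond the scatter. From the compounds shown here alone, it is also open whether chloro in place of methoxy would behave the same way elsewhere on the core.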